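The source may report more compounds than this note shows. Statements on the series, on what has been measured and on what is new or still open speak of the compounds shown alone.

Compound 1, `C=C1[C@@H](O)[C@H](n2cnc3c(N)ncnc32)O[C@@H]1CO`, gives 43000 nM in a functional assay on MT4 cells (Homo sapiens) for inhibition; a lower number here means a stronger inhibitor, a higher number a weaker inhibitor.
Compound 2, `C=C1[C@@H](O)[C@H](n2cnc3c(O)ncnc32)O[C@@H]1CO`, reaches only a limit of this assay, namely > 200000 nM.
Compound 3, `C=C1[C@H](n2cnc3c(N)nc(N)nc32)O[C@H](CO)[C@H]1O`, likewise reaches only a limit of this assay, namely > 500000 nM.

Compound 1 and compound 2 differ in one place: hydroxy in place of amino on an aromatic carbon. That change brought an at least 4.6-fold higher number from compound 1 to compound 2 (0.66 log units; beyond the scatter), and the step is only a lower bound because compound 2 sits at the limit of > 200000 nM in this assay, at which 1 of the 3 values shown sits. Compound 3 carries a different core from compound 1; the difference between the two cores is not broken down here. Compound 3 itself is bounded by the limit of > 500000 nM in this assay, at which 1 of the 3 values shown sits, so no number is known for it.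

Compound 4, `C=C1[C@H](n2cnc3c(O)nc(N)nc32)O[C@H](CO)[C@H]1O`, has not yet been measured in this assay. It differs from compound 3 by hydroxy in place of amino on an aromatic carbon. Among the measured compounds shown here, this is the same kind of change as the one from compound 1 to compound 2, though not the same: around the place of change, compound 3 additionally has the site meta to an amino group (1 heavy atom). Compound 3 is already beyond the reach of this assay, and the earlier step weakened the inhibitor, so compound 4 is expected to be no stronger, with an expected step that the limit leaves unreadable from compound 3 to compound 4. Compound 4 is estimated at 1500000 nM, between 400000 nM and 6000000 nM, and most likely reported only as a limit.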

Compound 4, half-maximal inhibitory concentration: 150000 nM
The estimate for compound 4 lay 10-fold (1.00 log units) above the measured number; the measured number lies below the stated range.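

Hydroxy in place of amino on an aromatic carbon brought an at least 3.3-fold lower number from compound 3 to compound 4 (0.52 log units; beyond the scatter) in this assay, so the change did not carry over from the core of compound 1 to the core of compound 3 with the same direction: the same change on two cores in this assay, an at least 4.6-fold higher number (0.66 log units; beyond the scatter) from compound 1 to compound 2 and an at least 3.3-fold lower number (0.52 log units; beyond the scatter) from compound 3 to compound 4, at least 15-fold (1.19 log units) apart, beyond the scatter of two such steps
The size of the new step stays unknown, since compound 3 has only a limit and no number: the limit of > 500000 nM in this assay, at which 1 of the 4 values shown sits.
The earlier step is likewise only a bound and the two cores differ in a way not broken down here, so the pair of steps shows that the direction turned over but not which feature of the cores turned it, and compound 2 also has only a limit: the limit of > 200000 nM in this assay, at which 1 of the 4 values shown sits.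

On these data alone, it remains open whether other groups on the same aromatic carbon, such as a methylamino group or a chlorine atom, would also behave differently on the two cores. As far as these compounds go, it also remains open which part of the difference between the two cores decides the direction of the change, and whether the turn would hold on any further core.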